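This account rests on a few compounds, and the source may have more. Where it says the series, first, only, none or still open, it means among the compounds named here.

Compound 3 `Cc1nc(N)c2c(I)cn([C@@H]3O[C@H](CO)[C@@H](O)[C@H]3O)c2n1` stands in a functional assay on HCT-116 cells (Homo sapiens), read by MTT assay, with a stated time of 72 h (on this read-out higher numbers stand for weaker inhibition and lower numbers for stronger inhibition), at a limit only, giving > 20000 nM, so its true value is not read. Compound 1 `Nc1nc(N)c2c(-c3ccsc3)cn([C@@H]3O[C@H](CO)[C@@H](O)[C@H]3O)c2n1` likewise reaches only a limit in this assay, > 20000 nM. Compound 2 `Cc1nc(N)c2c(-c3ccccc3)cn([C@@H]3O[C@H](CO)[C@@H](O)[C@H]3O)c2n1` also gives only a limit in this assay, > 100000 nM. For the measured compounds named here, the single measured step, a step that the two limits leave unreadable from compound 2 to compound 3, cannot be sized because both of its ends rest at the limit of > 100000 nM in this assay, at which 1 of the 3 values shown sits, and (the limit of > 20000 nM in this assay, at which 2 of the 3 values shown sit). Compound 4 `Cc1nc(N)c2c(-c3ccsc3)cn([C@@H]3O[C@H](CO)[C@@H](O)[C@H]3O)c2n1` differs from compound 3 by thiophen-3-yl in place of iodo on an aromatic carbon. Compound 1 already carries thiophen-3-yl and sits at a limit, so no readable step bears on this change. The step that the limit leaves unreadable from compound 3 to compound 4 is expected to be small. Compound 4 is thus expected to give about 30000 nM, within 10000 nM to 100000 nM, most likely again as a limit.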

Compound 4, half-maximal inhibitory concentration: > 20000 nM
Compound 4: only a limit was reported; the forecaster's own chance of this, stated with the estimate: 85%; the middle value does not contradict the limit.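

Compound 4 again gives only a limit, like compound 1, compound 2 and compound 3, so none of its steps to those compounds can be read in this assay. The compounds shown leave open whether iodo, phenyl, thiophen-3-yl, amino or methyl changes inhibition at all.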